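The source may hold more compounds than are shown below. What is called first, only, known or untested is meant among the compounds shown, and "the series" means these compounds.

In a functional assay on COLO 205 cells (Homo sapiens) for inhibition, read by sulforhodamine B assay, with a stated time of 48 h (on this read-out lower numbers stand for stronger inhibition of growth and higher numbers for weaker inhibition of growth), compound 1, `COc1cc(-c2nn(-c3cccc(NC(=O)Nc4cc(C(F)(F)F)cc(C(F)(F)F)c4)c3)cc2-c2ccncc2)ccc1Cl`, gives 1570 nM. Within the data shown here, compound 2, `COc1cc(-c2nn(-c3cccc(NC(=O)Nc4ccc(Cl)c(Cl)c4)c3)cc2-c2ccncc2)ccc1Cl`, gives 1720 nM in this assay, a number that sits within the usual scatter of the one for compound 1. The difference between the core of compound 1 and the core of compound 2 is not broken down here. Compound 3, `O=C(Nc1cccc(-n2cc(-c3ccncc3)c(-c3ccc(Cl)c(O)c3)n2)c1)Nc1ccc(Cl)c(Cl)c1`, gives 9490 nM in this assay. Compound 3 differs from compound 2 by hydrogen in place of methyl on an oxygen on an aromatic ring, and this change made a step of a 5.5-fold higher number from compound 2 to compound 3 (0.74 log units; beyond the scatter).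

Compound 4, `O=C(Nc1cccc(-n2cc(-c3ccncc3)c(-c3ccc(Cl)c(O)c3)n2)c1)Nc1cc(C(F)(F)F)cc(C(F)(F)F)c1`, has not yet been measured in this assay. Among the measured compounds shown here, it differs from compound 1 by hydrogen in place of methyl on an oxygen on an aromatic ring, which is the same change, at the same kind of place, as the one that separates compound 2 from compound 3. Because that change produced a 5.5-fold higher number from compound 2 to compound 3 (0.74 log units; beyond the scatter) on a core that otherwise behaved much like the core of compound 1, the expected step from compound 1 to compound 4 is a 5.5-fold higher number from compound 1 to compound 4 (0.74 log units; beyond the scatter), of a size beside the earlier one. On that basis compound 4 is expected to give about 8600 nM in this assay, with a range estimated from 4000 nM to 18000 nM.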

Compound 4, concentration for total growth inhibition: 1580 nM
For compound 4 the middle estimate is 5.4-fold (0.74 log units) above the measured one; measured number outside the range, below it.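

In this assay, the swap of 4-chloro-3-methoxyphenyl to 4-chloro-3-hydroxyphenyl on the core of compound 1 gave a 1.0-fold higher number from compound 1 to compound 4 (0.00 log units; within the scatter), so this core showed no measurable response to a change that had a clear effect on the core of compound 2. Among these compounds, the change therefore did not carry from one core to the other with the same size, and the two steps differ by more than the scatter allows: the same change on two cores in this assay, a 5.5-fold higher number (0.74 log units; beyond the scatter) from compound 2 to compound 3 and a 1.0-fold higher number (0.00 log units; within the scatter) from compound 1 to compound 4, 5.5-fold (0.74 log units) apart, beyond the scatter of two such steps This shows that, in this small series, a step measured on one core cannot simply be transferred to another, but with only two pairs it does not show which difference between the cores sets the size of the step, why the two outcomes part, or how the change would behave on any further core.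

The compounds shown leave open whether an ethoxy group, an amine or a carboxylic acid at the same place on the aromatic ring would also depend on the core in this way. They also leave open whether the contrast between the two cores would persist in any assay other than this assay.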